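Extending the alkyl chain of a trifluoromethylphenyl thiourea

The source may report more compounds than this note shows. Statements on the series, on what has been measured and on what is new or still open speak of the compounds shown alone.

Three thioureas were measured in an ADME assay on Vero 76 cells (Chlorocebus sabaeus) for cytotoxicity, read by crystal violet staining, with a stated time of 96 h; on this read-out higher numbers stand for lower toxicity in this test and lower numbers for higher toxicity in this test. Compound 1 `FC(F)(F)c1cccc(NC(=S)Nc2cccc(Br)c2)c1` gives 14000 nM. Compound 2 `COc1cccc(NC(=S)Nc2cccc(C(F)(F)F)c2)c1` gives 20000 nM, and the step of a 1.4-fold higher number from compound 1 to compound 2 (0.15 log units; within the scatter) stays within the scatter. Compound 3 `CCNC(=S)Nc1cccc(C(F)(F)F)c1` reports only a limit, > 100000 nM, so its true value is not a number (the limit of > 100000 nM in this assay, at which 1 of the 3 values shown sits). The step of an at least 7.1-fold higher number from compound 1 to compound 3 (0.85 log units; beyond the scatter) is the only one beyond the scatter. Compound 4 `C=C(C)CNC(=S)Nc1cccc(C(F)(F)F)c1` is not yet measured; it differs from compound 3 by 1-methylethenyl in place of methyl on a saturated chain carbon bound to an amide-type nitrogen. For the measured compounds named here, no measured step alters a chain on the amide-type nitrogen, so the account has nothing that bears directly on this change. Compound 4 is expected to remain at or near the limit, an estimated 100000 nM (40000 nM to 100000 nM), a step of a number no higher from compound 3 to compound 4 (the limit leaves the size open).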

Compound 4, half-maximal cytotoxic concentration: > 100000 nM
Compound 4 was reported as a limit; the forecaster's own chance of this, stated with the estimate: 70%; the middle value sits exactly at the limit.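

In this assay compound 4 also gives only a limit and not a number: the limit of > 100000 nM in this assay, at which 2 of the 4 values shown sit. The step between compound 3 and compound 4 cannot be read, as both values are limits. Putting 2-methylprop-2-en-1-yl in place of 3-bromophenyl on the amide-type nitrogen gives an at least 7.1-fold higher number from compound 1 to compound 4 (0.85 log units; beyond the scatter) and so ethyl is no longer the only chain there that reaches this limit.

On these data alone, whether a longer saturated chain, or an amine or a carboxylic acid on the chain, would bring the number down from the limit stays open. So does whether compound 3 and compound 4 differ at all.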